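A few compounds are considered here, and "the series" means these few. Any claim that something is new, unique, unknown or untested is made for them only; others in the source may bear on it.

In an ADME assay on MDCK cells (Canis lupus familiaris) for cytotoxicity, read by MTT assay, with a stated time of 48 h (a higher number here means that more compound is tolerated, a lower number that less compound is tolerated), compound 2 (`FC(F)(F)Oc1ccc(-c2cn(CC3=C(Cl)c4ccc(-c5cccs5)nc4CC3)nn2)cc1`) gives > 300 ug/mL which is a limit of the assay and not a number. On these data alone, compound 2 thus stands at the limit of > 300 ug/mL in this assay, at which 1 of the 3 values shown sits, and its exact place is unknown. Compound 1 (`Fc1ccc(-c2cn(CC3=C(Cl)c4ccc(-c5cccs5)nc4CC3)nn2)c(F)c1`) gives 188 ug/mL in this assay for comparison. For the measured compounds named here, the one measured step is an at least 1.5-fold higher number from compound 1 to compound 2 (0.20 log units; that floor lies within the scatter) and it is the only step that bears on this group directly. Compound 3 (`FC(F)(F)c1cc(-c2cn(CC3=C(Cl)c4ccc(-c5cccs5)nc4CC3)nn2)cc(C(F)(F)F)c1`) gives 35 ug/mL so a much lower number is also possible on the shared core. Compound 4 (`ClC1=C(Cn2cc(-c3ccsc3)nn2)CCc2nc(-c3cccs3)ccc21`) has thiophen-3-yl in place of 4-(trifluoromethoxy)phenyl on an aromatic carbon. Going by the values given here, no measured step covers thiophen-3-yl, so the expectation rests on the values of compound 1 (188 ug/mL) and compound 3 (35 ug/mL). A downward move into the measurable range is therefore expected, with the estimated step being an at least 1.8-fold lower number from compound 2 to compound 4 (0.27 log units; that floor lies within the scatter) in this assay here. For compound 4 the estimate is 160 ug/mL (expected range 60 ug/mL to 300 ug/mL).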

Compound 4, half-maximal cytotoxic concentration: > 300 ug/mL
Compound 4 ended at the assay's limit; the forecaster's own chance of this, stated with the estimate: 20%; middle value at least 1.8-fold (0.27 log units) away from the limit.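

In this assay compound 4 gives > 300 ug/mL, which is a limit of the assay and not a number. Against 2,4-difluorophenyl, thiophen-3-yl gives an at least 1.5-fold higher number from compound 1 to compound 4 (0.20 log units; that floor lies within the scatter), while the step between the two limits cannot be read. On the five-membered aromatic ring with 3 nitrogen, the top of the readable range is thus reached with a five-membered aromatic ring with 1 hetero atom as well as with a six-membered aromatic ring of carbon only: the limit of > 300 ug/mL in this assay, at which 2 of the 4 values shown sit.

Where compound 2 and compound 4 truly lie relative to each other stays open, and so does whether thiophen-2-yl would behave like thiophen-3-yl. On these data alone, it is also open whether a non-aromatic group at this position, such as an aminomethyl chain or a carboxylic acid, would stay at this limit or fall toward the value of compound 3. In this assay compound 3 gives 35 ug/mL.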